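The source may report more compounds than this note shows. Statements on the series, on what has been measured and on what is new or still open speak of the compounds shown alone.

Measured so far in a functional assay on B16 cells (Mus musculus) for inhibition; a higher number here means a weaker inhibitor, a lower number a stronger inhibitor:
- compound 1 `COc1cc(/C=C/C(=O)c2cccc(NC(=O)c3c(Cl)cccc3Cl)c2)ccc1O`: 1.58 ug/mL
- compound 2 `COc1cc(/C=C/C(=O)c2cccc(NC(=O)c3cc(Cl)cc(Cl)c3)c2)ccc1O`: 4.83 ug/mL
- compound 3 `COc1cc(/C=C/C(=O)c2cccc(NC(=O)c3ccc(Cl)cc3Cl)c2)ccc1O`: 12.8 ug/mL

Compound 3 is the weakest inhibitor of the three, with a 2.7-fold higher number from compound 2 to compound 3 (0.42 log units; beyond the scatter) and an 8.1-fold higher number from compound 1 to compound 3 (0.91 log units; beyond the scatter), both beyond the scatter. Compound 4 `COc1cc(/C=C/C(=O)c2cccc(NC(=O)C(C)C)c2)ccc1O` differs from it by isopropyl in place of 2,4-dichlorophenyl on a carbonyl carbon, with isopropyl in place of 2,4-dichlorophenyl on a carbonyl carbon.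

Within the data shown here, no measured step makes this kind of change. The nearest evidence is a 3.1-fold higher number from compound 1 to compound 2 (0.49 log units; beyond the scatter), together with the two steps above, and each of these only exchanges one dichlorophenyl for another. They therefore give a scale of modest steps but no firm direction. The expected direction leans toward a lower number, since compound 3 sits at 12.8 ug/mL, the top of the measured numbers.

The estimated change is a modest one, a 1.8-fold lower number from compound 3 to compound 4 (0.26 log units; within the scatter), and it remains uncertain. For compound 4 the expected value is 7 ug/mL, with an estimated range from 2 ug/mL to 25 ug/mL.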

Compound 4, half-maximal inhibitory concentration: 1.09 ug/mL
Compound 4: the middle estimate sits 6.4-fold (0.81 log units) above what was measured; measured number below the stated range.
By their numbers in this assay, from the lowest: compounds 4 and 1 (each within the scatter of the next); then compound 2; then compound 3.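

In this assay, this position on the carbonyl carbon proves not to depend on an aromatic ring, since isopropyl, with no ring and only three carbons, gives a 12-fold lower number from compound 3 to compound 4 (1.07 log units; beyond the scatter) and a 4.4-fold lower number from compound 2 to compound 4 (0.65 log units; beyond the scatter). The earlier compounds shown here showed only that moving the chlorines around the ring shifts the number; this change shows that losing the whole dichlorophenyl group can still leave a low number, with a 1.4-fold lower number from compound 1 to compound 4 (0.16 log units; within the scatter). No measurement in hand accounts for this result.

What the compounds leave open is whether the low number holds for other non-aromatic groups at this place, such as cyclopropyl, tert-butyl or a longer chain like n-butyl. They also leave open how an unsubstituted phenyl would compare with the dichlorophenyl groups and with isopropyl.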